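From compound 1 to compound 3: methyl replaced

This account rests on a few compounds, and the source may have more. Where it says the series, first, only, none or still open, it means among the compounds named here.

compound 1 `Cc1c2c(n3c1CCN(C)C[C@@H](C)[C@H](C)Nc1cc-3ccc1C(N)=O)CC(C)(C)CC2=O` with 27 nM
compound 2 `Cc1c2c(n3c1CCN(C(=O)C1(N)CCCC1)C[C@@H](C)[C@H](C)Nc1cc-3ccc1C(N)=O)CC(C)(C)CC2=O` with 26 nM

In a functional assay on NCI-H1975 cells (Homo sapiens) for antiproliferative activity (on this read-out lower numbers stand for stronger inhibition and higher numbers for weaker inhibition), compound 1 gives 27 nM and compound 2 gives 26 nM as its value. Among the measured compounds shown here, these two numbers lie within the scatter of each other, so compound 1 stands level with the only other compound measured so far. The change in question leads to compound 3 `Cc1c2c(n3c1CCN(C(=O)[C@H](C)O)C[C@@H](C)[C@H](C)Nc1cc-3ccc1C(N)=O)CC(C)(C)CC2=O`, not yet measured, and it is this: (1-hydroxyethyl)carbonyl in place of methyl on an amine nitrogen in a ring. In words, (1-hydroxyethyl)carbonyl takes the place of methyl on an amine nitrogen in a ring. For the measured compounds named here, one measured step bears on it, a 1.0-fold lower number from compound 1 to compound 2 (0.02 log units; within the scatter), which made its change at the same place and stayed within the scatter. Going by the values given here, the group entering compound 3 differs from the one in compound 2, and a single pair is thin evidence. Even so, no step beyond the scatter is expected in this assay in either direction. The expected change is a 1.1-fold higher number from compound 1 to compound 3 (0.05 log units; within the scatter) as estimated here. For compound 3 the estimated value is 30 nM, with an expected range from 12 nM to 75 nM as its limits of expectation.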

Compound 3, half-maximal inhibitory concentration: 52 nM
Compound 3: the middle estimate sits 1.7-fold (0.24 log units) below what was measured; measured number inside the range.
By their numbers in this assay, from the lowest: compounds 2, 1 and 3 (each within the scatter of the next).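

In this assay, putting (1-hydroxyethyl)carbonyl in place of methyl on the amine nitrogen in the ring gives a 1.9-fold higher number from compound 1 to compound 3 (0.28 log units; within the scatter), and putting 1-hydroxyethyl in place of 1-aminocyclopentyl on the carbonyl carbon gives a 2.0-fold higher number from compound 2 to compound 3 (0.30 log units; within the scatter). This position has now carried a second carbonyl-linked group, one with no ring and a defined stereocentre, and neither step leaves the scatter, so the tolerance seen with compound 2 is not confined to the 1-aminocyclopentyl group. No measurement is at hand that would explain these numbers.

On these data alone, it remains open whether a longer chain or a carboxylic acid on the carbonyl carbon, or a sulfonyl group directly on the ring nitrogen, would also stay within the scatter of compound 1, and what the opposite configuration at the stereocentre of the 1-hydroxyethyl group would give. The compounds shown also say nothing about how these changes behave outside this assay, since that is the only read-out available for them.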